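The source may hold more compounds than are shown below. What is called first, only, known or untested is meant among the compounds shown, and "the series" means these compounds.

In a physicochemical assay for lipophilicity, using the shake flask method, at pH 7.4 (a higher number here means a more lipophilic compound, a lower number a more polar compound), compound 1 (`O=C(O)CCNC(=O)c1ccc(C(Oc2ccc(-n3cc(C(F)(F)F)cn3)cc2)C2CCCC2)cc1`), with a cyclopentyl group, gives 3.3 and compound 2 (`CCCC(Oc1ccc(-n2cc(C(F)(F)F)cn2)cc1)c1ccc(C(=O)NCCC(=O)O)cc1`), with a propyl group in its place, gives 2.4 as the lower of the two numbers. Compound 3 (`CCCC(Oc1ccc(-n2cc(C(F)(F)F)cn2)c(C)c1)c1ccc(C(=O)NCCC(=O)O)cc1`) follows from compound 2 through a single change (methyl in place of hydrogen on an aromatic carbon), a methyl in place of hydrogen on an aromatic carbon, ortho to a 4-(trifluoromethyl)-1H-pyrazol-1-yl group. Within the data shown here, only one measured step offers any guidance. It is a number 0.90 log units lower from compound 1 to compound 2 (beyond the scatter) and it lies at a saturated chain carbon, a different place from the new methyl, so it is only a loose guide. It does show that exchanging one carbon-only group for another can move this number beyond the scatter. Adding a methyl is a smaller alteration than trading cyclopentyl for propyl, so a rise well short of that step seems likely, although no measured step tests this position. The expected move is a number 0.40 log units higher from compound 2 to compound 3 (beyond the scatter) as a modest rise. In this assay the estimate for compound 3 is 2.8 (expected range 2.4 to 3.2).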

Compound 3, distribution coefficient: 2.6
Estimate against measurement, compound 3: 0.20 log units above; measured number inside the range.
By their numbers in this assay, from the lowest: compounds 2 and 3 (each within the scatter of the next); then compound 1.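

In this assay, putting a methyl in place of hydrogen on an aromatic carbon, ortho to a 4-(trifluoromethyl)-1H-pyrazol-1-yl group, gives a number 0.20 log units higher from compound 2 to compound 3 (within the scatter) and so leaves compounds 2 and 3 indistinguishable by this measurement. Among these compounds, the only earlier step, at a saturated chain carbon, was a number 0.90 log units lower from compound 1 to compound 2 (beyond the scatter) and lay beyond the usual spread of repeat measurements, whereas this first reading on the six-membered aromatic ring shows that a small carbon-only addition at this position need not shift the number measurably. Nothing available here explains either result.

What the compounds shown leave open is whether a larger group at this position, such as an ethyl group or a methoxy group, or a chlorine atom in the same place, would also stay within the spread of repeat measurements. Going by these compounds, it is equally open whether a methyl on a different aromatic carbon of this ring, or the same methyl added to the cyclopentyl compound 1, would behave as it does here.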